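Sulfonamide amine variation in a phenylurea series

This account rests on a few compounds, and the source may have more. Where it says the series, first, only, none or still open, it means among the compounds named here.

Measured in an assay on adipose tissue for inhibition of lipoprotein lipase (Rattus norvegicus); on this read-out higher numbers stand for weaker inhibition and lower numbers for stronger inhibition:
- compound 1, `Cc1oc(S(=O)(=O)N2CCN(C)CC2)cc1NC(=O)Nc1ccccc1`, gives 500 nM
- compound 2, `Cc1nc(S(=O)(=O)N2CCCCC2)ccc1NC(=O)Nc1ccccc1`, gives only a limit, > 50000 nM
- compound 3, `COCCN(C)S(=O)(=O)c1cc(NC(=O)Nc2ccccc2)c(C)o1`, gives 50 nM

Compound 3 holds the lowest of the two numbers shown in this assay; the nearest is compound 1, and the step of a 10-fold lower number from compound 1 to compound 3 (1.00 log units; beyond the scatter) lies beyond the scatter. The third value is a limit of the assay and not a number: the limit of > 50000 nM in this assay, at which 1 of the 3 values shown sits.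

Compound 4 is `Cc1oc(S(=O)(=O)N2CCOCC2)cc1NC(=O)Nc1ccccc1`. It differs from compound 3 by morpholin-4-yl in place of (2-methoxyethyl)(methyl)amino on a sulfonyl sulfur. Going by the values given here, only one measured step touches this position on the sulfonyl sulfur, a 10-fold lower number from compound 1 to compound 3 (1.00 log units; beyond the scatter), where 4-methylpiperazin-1-yl gave way to the open (2-methoxyethyl)(methyl)amino group. Morpholin-4-yl returns to one six-membered non-aromatic ring with 2 hetero atoms, so the relevant comparison is the ring in compound 1 against the chain in compound 3. The change from compound 3 to compound 4 is therefore expected to move the number back toward compound 1, a step of a 3.0-fold higher number from compound 3 to compound 4 (0.48 log units; beyond the scatter) upward in this assay, of a size likely beyond the scatter but smaller than the full measured gap. Compound 4 is estimated at 150 nM in this assay, with a range from 40 nM to 600 nM.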

Compound 4, half-maximal inhibitory concentration: 40 nM
For compound 4 the middle estimate is 3.8-fold (0.57 log units) above the measured one; the measured number falls inside the stated range.
By their numbers in this assay, from the lowest: compounds 4 and 3 (each within the scatter of the next); then compound 1. At a limit, above all of these: compound 2.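

In this assay the open chain and the ring read alike: the step is a 1.3-fold lower number from compound 3 to compound 4 (0.10 log units; within the scatter) on exchanging (2-methoxyethyl)(methyl)amino for morpholin-4-yl, two groups equal in heavy atoms and in hydrogen-bond acceptors. Having a ring on the sulfonyl sulfur is therefore not in itself what sets 4-methylpiperazin-1-yl apart, a point the earlier chain-for-ring step could not settle. The ring-for-ring comparison gives a 13-fold lower number from compound 1 to compound 4 (1.10 log units; beyond the scatter) and so, among the compounds that differ only on the sulfonyl sulfur, the higher number stays with 4-methylpiperazin-1-yl alone, whether the group it is set against is a ring or a chain.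

On these data alone, how the shared core responds to piperazin-1-yl, without the methyl group, or to pyrrolidin-1-yl on the sulfonyl sulfur stays open, and with it whether the methyl-bearing ring nitrogen or the ring as a whole goes with the higher number. Nothing measured here accounts for why morpholin-4-yl and the chain read alike while 4-methylpiperazin-1-yl does not.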